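Methyl for Fluoro on the Amide Aryl Ring

The source may report more compounds than this note shows. Statements on the series, on what has been measured and on what is new or still open speak of the compounds shown alone.

Compound 1 `Cc1c(C(=O)Nc2ccc(F)c(F)c2)sc(N)c1C#N`: > 100000 nM
Compound 2 `Cc1cc(NC(=O)c2sc(N)c(C#N)c2C)ccc1F`: 96000 nM
Compound 3 `Cc1c(C(=O)Nc2ccccc2)sc(N)c1C(=O)Nc1ccc(F)c(F)c1`: 40000 nM

In an ADME assay on HepG2 cells (Homo sapiens) for cytotoxicity, read by XTT assay, with a stated time of 2 days (a higher number here means that more compound is tolerated, a lower number that less compound is tolerated), compound 1 gives > 100000 nM, which is a limit of the assay rather than a number. Compound 2 gives 96000 nM in this assay, and compound 3 gives 40000 nM. The change from compound 1 to compound 2 is methyl in place of fluoro on an aromatic carbon, and it gave an at least 1.0-fold lower number from compound 1 to compound 2 (0.01 log units; that floor lies within the scatter). Compound 4 `Cc1cc(NC(=O)c2c(N)sc(C(=O)Nc3ccccc3)c2C)ccc1F` differs from compound 3 by methyl in place of fluoro on an aromatic carbon, the same change in the same surroundings; how the core of compound 3 differs from that of compound 1 is not broken down here. For the measured compounds named here, since the one measured step, an at least 1.0-fold lower number from compound 1 to compound 2 (0.01 log units; that floor lies within the scatter), stayed within the scatter, compound 4 is expected to sit near compound 3, with no change at the digits printed from compound 3 to compound 4 (within the scatter) as the estimated step. Compound 4 is therefore estimated at 40000 nM, between 15000 nM and 100000 nM.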

Compound 4, half-maximal cytotoxic concentration: 40000 nM
The estimate for compound 4 equals the measured number at the digits printed, and the stated range covers the measured number.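

In this assay, methyl in place of fluoro on the aromatic ring gave no change at the digits printed from compound 3 to compound 4 (within the scatter). Set beside the earlier step, the swap shows no measurable shift on either core, though the comparison has a limit built into it: the same change on two cores in this assay, an at least 1.0-fold lower number (0.01 log units; that floor lies within the scatter) from compound 1 to compound 2 and no change at the digits printed (within the scatter) from compound 3 to compound 4; the limit leaves it open whether they differ Compound 1 carries a limit rather than a number, so the size of the first step stays unknown and the two cores cannot be called equal in their response: the limit of > 100000 nM in this assay, at which 1 of the 4 values shown sits.

The compounds shown cover only two cores and only this one swap, so nothing here tells how the change would fare on a third core. They also leave open whether a larger change at this place on the ring, such as an amine or a carboxylic acid, would shift the number.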